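Notes on the step from compound 3 to compound 4

This account rests on a few compounds, and the source may have more. Where it says the series, first, only, none or still open, it means among the compounds named here.

Measured in an ADME assay on L132 cells (Homo sapiens) for cytotoxicity, read by MTT assay, with a stated time of 48 h; on this read-out lower numbers stand for stronger inhibition and higher numbers for weaker inhibition:
- compound 1 `C/C(=C\CC/C(C)=C/CC[C@@H]1[C@@]2(C)CCC(=O)C(C)(C)[C@H]2CC[C@@]1(C)O)CC/C=C(\C)C(=O)OCc1cn(-c2ccc(F)cc2)nn1` gives > 150000 nM (a limit)
- compound 2 `C/C(=C\CC/C(C)=C/CC[C@@H]1[C@@]2(C)CCC(=O)C(C)(C)[C@H]2CC[C@@]1(C)O)CC/C=C(\C)C(=O)OCc1cn(-c2ccc([N+](=O)[O-])cc2)nn1` gives > 150000 nM (a limit)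
- compound 3 `C/C(=C\CC/C(C)=C/CC[C@@H]1[C@@]2(C)CCC(=O)C(C)(C)[C@H]2CC[C@@]1(C)O)CC/C=C(\C)C(=O)OCc1cn(-c2ccccc2C)nn1` gives > 150000 nM (a limit)

Compound 3 has no number in this assay, only the limit > 150000 nM and nothing more. The series as a whole stands at the limit of > 150000 nM in this assay, at which 3 of the 3 values shown sit, and so offers no ranking of its members.

The change to compound 4 `C/C(=C\CC/C(C)=C/CC[C@@H]1[C@@]2(C)CCC(=O)C(C)(C)[C@H]2CC[C@@]1(C)O)CC/C=C(\C)C(=O)OCc1cn(-c2cccc(Br)c2)nn1` is 3-bromophenyl in place of 2-methylphenyl on an aromatic nitrogen and places 3-bromophenyl where 2-methylphenyl stood on an aromatic nitrogen. For the measured compounds named here, three measured steps bear on it, since each also exchanges the group on that nitrogen or a substituent of it. They are a step that the two limits leave unreadable from compound 1 to compound 2, a step that the two limits leave unreadable from compound 1 to compound 3 and a step that the two limits leave unreadable from compound 2 to compound 3, and none of them has a size that can be read.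

Going by the values given here, compound 4 is therefore expected to stay with compound 3 , whose > 150000 nM reading is the only guide. The expected change is a step that the limit leaves unreadable from compound 3 to compound 4, and no direction can be predicted from these data. A report of only a limit is the likeliest result. The estimated value for compound 4 is 170000 nM, with an expected range from 80000 nM to 300000 nM as the outcome.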

Compound 4, half-maximal inhibitory concentration: > 150000 nM
Compound 4: only a limit was reported; the forecaster's own chance of this, stated with the estimate: 85%; the middle value lies beyond the limit too.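

In this assay compound 4 gives > 150000 nM, which is a limit and not a number. Its steps from compound 1, compound 2 and compound 3 therefore cannot be read, and the series still offers no ranking: the limit of > 150000 nM in this assay, at which 4 of the 4 values shown sit.

The compounds shown leave open whether exchanging the group on the aromatic nitrogen changes cytotoxicity at all.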